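The source may report more compounds than this note shows. Statements on the series, on what has been measured and on what is new or still open speak of the compounds shown alone.

Going by the values given here, in a functional assay on HeLa cells (Homo sapiens) for inhibition, read by CCK-8 assay, with a stated time of 72 h (on this read-out lower numbers stand for stronger inhibition and higher numbers for weaker inhibition), two compounds have numbers so far. Compound 1 (`O=C(/C=C/c1cccnc1)NCCCCCc1cccc(S(=O)(=O)Nc2ccccc2)c1`) gives 105 nM and compound 2 (`O=C(/C=C/c1cccnc1)NCCCCCCc1cccc(S(=O)(=O)Nc2ccccc2)c1`) stands at 30.4 nM and so holds the lower of the two numbers. The gap between them lies beyond the usual scatter of repeated measurements.

The next compound is compound 3 (`Cc1ccccc1NS(=O)(=O)c1cccc(CCCCCCNC(=O)/C=C/c2cccnc2)c1`), which keeps all of compound 2 except in one place. The change methyl in place of hydrogen on an aromatic carbon turns anilino into (2-methylphenyl)amino: methyl in place of hydrogen on an aromatic carbon, ortho to a large group. Among the compounds with values here, no measured pair in this small set shows what such a change does in this assay and the data give no direction for it. The expectation therefore starts from compound 2 at 30.4 nM and allows a modest move either way. The expected step is a 1.2-fold higher number from compound 2 to compound 3 (0.06 log units; within the scatter) and it would stay within the scatter. Compound 3 is expected to read 35 nM within an estimated range of 13 nM to 95 nM once it is tested.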

Compound 3, half-maximal inhibitory concentration: 2.34 nM
Compound 3: the middle estimate sits 15-fold (1.17 log units) above what was measured; the whole stated range lies above it.
By their numbers in this assay, from the lowest: compound 3; then compound 2; then compound 1.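

In this assay, going by these compounds alone, the change from phenylsulfamoyl to (2-methylphenyl)sulfamoyl is the first change in a single place that can be read in this set, and it gives a 13-fold lower number from compound 2 to compound 3 (1.11 log units; beyond the scatter) in a large step. This shows that the ring carbon ortho to a large group accepts a methyl and that this position responds strongly, since one added carbon, with no hydrogen-bond donor or acceptor and no net charge, moves the number this far. Nothing shown here bears on the reason for the step.

Whether the step belongs to methyl in particular stays open, since no compound shown carries an ethyl, a methoxy or a chlorine on that same carbon, and none carries a methyl on another carbon of that ring. Going by these compounds, it is also open whether the same methyl would give a step of this size on the chain of compound 1, and whether a second methyl on the other ortho carbon would add to it or take it away.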